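Cytotoxicity at the assay limit: hydrogen in place of iodo

The source may report more compounds than this note shows. Statements on the series, on what has been measured and on what is new or still open speak of the compounds shown alone.

In an ADME assay on Huh-7 cells (Homo sapiens) for cytotoxicity, read by XTT assay (on this read-out lower numbers stand for higher toxicity in this test and higher numbers for lower toxicity in this test), compound 3 `CCc1cn([C@H]2C[C@H](I)[C@@H](CO)O2)c(=O)[nH]c1=O` gives > 100 ug/mL, which is a limit and not a number. Compound 1 `CCc1cn([C@H]2C[C@H](N=[N+]=[N-])[C@@H](CO)O2)c(=O)[nH]c1=O` gives > 100 ug/mL, also a limit. Compound 2 `Cc1cn([C@H]2C[C@H](N)[C@@H](CO)O2)c(=O)[nH]c1=O` gives > 100 ug/mL, again a limit. The series therefore stands as the limit of > 100 ug/mL in this assay, at which 3 of the 3 values shown sit.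

Compound 4 `CCc1cn([C@H]2CC[C@@H](CO)O2)c(=O)[nH]c1=O` has hydrogen in place of iodo on a saturated ring carbon. Among the compounds with values here, the one measured step involving the iodo group is a step that the two limits leave unreadable from compound 1 to compound 3, so it offers no size to carry over. No step beyond the scatter can be forecast, and no direction is expected. The expected step is a step that the limit leaves unreadable from compound 3 to compound 4. The estimate for compound 4 is 150 ug/mL, with an expected range of 80 ug/mL to 400 ug/mL.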

Compound 4, half-maximal cytotoxic concentration: > 100 ug/mL
Compound 4 ended at the assay's limit; the forecaster's own chance of this, stated with the estimate: 85%; the middle value does not contradict the limit.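

No step can be read among compound 1, compound 3 and compound 4 in this assay: the limit of > 100 ug/mL in this assay, at which 4 of the 4 values shown sit.

The compounds shown leave open whether azido, iodo and hydrogen on the saturated ring carbon differ at all in this assay.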